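Hydroxy to amino swap on two related cores

The source may hold more compounds than are shown below. What is called first, only, known or untested is meant among the compounds shown, and "the series" means these compounds.

Compound 1, `COc1ccc(-c2ssc(=S)c2-c2cc(OC)c(OC)c(OC)c2)cc1O`, and compound 2, `COc1ccc(-c2ssc(=S)c2-c2cc(OC)c(OC)c(OC)c2)cc1N`, share one core and differ only at a single aromatic position: amino in place of hydroxy on an aromatic carbon. In a functional assay on KB cells (Homo sapiens) for antiproliferative activity, read by MTT assay, with a stated time of 72 h (on this read-out lower numbers stand for stronger inhibition and higher numbers for weaker inhibition), compound 1 gives 435 nM, and compound 2 gives 327 nM. The step of a 1.3-fold lower number from compound 1 to compound 2 (0.12 log units; within the scatter) is within the scatter, so the two are read as equivalent on this read-out.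

Compound 3, `CO/N=c1/ssc(-c2ccc(OC)c(O)c2)c1-c1cc(OC)c(OC)c(OC)c1`, carries the hydroxy analogue of the same aryl group on a different core; the difference between the two cores is not broken down here. In this assay compound 3 gives 14500 nM, the highest number of the three measured, well beyond the scatter from both compound 1 and compound 2.

Compound 4, `CO/N=c1/ssc(-c2ccc(OC)c(N)c2)c1-c1cc(OC)c(OC)c(OC)c1`, is not yet measured. It relates to compound 3 exactly as compound 2 relates to compound 1: amino in place of hydroxy on an aromatic carbon. The place lines match word for word, so this is the same change made on the second core.

The expectation rests on one precedent only: the hydroxy-to-amino exchange on the first core produced a 1.3-fold lower number from compound 1 to compound 2 (0.12 log units; within the scatter), a step too small to separate from repeat-measurement noise. Among the measured compounds shown here, with no further example, the estimate assumes the second core behaves the same way, so compound 4 is expected to stay near compound 3, giving an expected step of a 1.3-fold lower number from compound 3 to compound 4 (0.12 log units; within the scatter). Compound 4 is therefore estimated at 11000 nM in this assay, with a plausible range from 5000 nM to 25000 nM.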

Compound 4, half-maximal inhibitory concentration: 4330 nM
Estimate against measurement, compound 4: 2.5-fold (0.40 log units) above, outside the stated range (below it).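

On the second core, in this assay, going from 3-hydroxy-4-methoxyphenyl to 3-amino-4-methoxyphenyl gives a 3.3-fold lower number from compound 3 to compound 4 (0.52 log units; beyond the scatter), a modest step that taken alone lies beyond the scatter. Set beside the step on the first core, it does not stand apart, so the two cores cannot be told apart in their response to this exchange: the same change on two cores in this assay, a 1.3-fold lower number (0.12 log units; within the scatter) from compound 1 to compound 2 and a 3.3-fold lower number (0.52 log units; beyond the scatter) from compound 3 to compound 4, 2.5-fold (0.40 log units) apart, within the scatter of two such steps. This shows that the exchange costs no inhibition on either core and that the precedent from the first core carries over within the limits of the scatter, but it does not show that the amino group gains more on the second core than on the first, and two pairs give no rule for any further core.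

The compounds shown leave open how other groups on this aromatic carbon, such as a methylamino group, an acetamido group or a fluorine atom, would compare with hydroxy and amino on either core. Among the compounds shown here, they also leave open which feature of the two cores sets their numbers so far apart, since each pair here tests only the exchange on the aryl group and not the core itself.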